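Shortening the amine-bearing chain on a shared core

A few compounds are considered here, and "the series" means these few. Any claim that something is new, unique, unknown or untested is made for them only; others in the source may bear on it.

Of the compounds shown here, three built on one shared core have been measured in an assay on HEK293 cells for inhibition of Steryl-sulfatase (Homo sapiens), tested at 0.1 uM; a higher number here means a stronger effect of the compound at the concentration tested, a lower number a weaker effect. Compound 1 `CN(C)CCCN(Cc1ccccc1)c1cccc(C(=O)N2CCc3ccc(OS(N)(=O)=O)cc3C2)c1` gives 23.8%. Compound 2 `CC(C)CCN(CCC(C)C)c1cccc(C(=O)N2CCc3ccc(OS(N)(=O)=O)cc3C2)c1` gives 32.3%, a number within the scatter of that of compound 1. Compound 3 `CCCN(CCC)c1cccc(C(=O)N2CCc3ccc(OS(N)(=O)=O)cc3C2)c1` gives 8.3%, so compound 1 stands second highest of the three, its reading higher than that of compound 3 beyond the scatter.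

Compound 4 `CN(C)CCN(Cc1ccccc1)c1cccc(C(=O)N2CCc3ccc(OS(N)(=O)=O)cc3C2)c1` differs from compound 1 in one place: dimethylamino in place of (dimethylamino)methyl on a saturated chain carbon, two bonds along the chain from a nitrogen on an aromatic ring. Among the measured compounds shown here, the only measured step that changes a substituent on the same nitrogen on an aromatic ring is a number 24 percentage points lower from compound 2 to compound 3 (beyond the scatter), where a shorter pair of chains went with a lower reading. That step bears on the present one only loosely, since the chains differ in kind, yet it points downward. A small decrease is therefore expected, and the estimated step is a number 6.8 percentage points lower from compound 1 to compound 4 (within the scatter). Compound 4 is expected to give about 17%, within a range from 4% to 30%.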

Compound 4, a percentage reported as inhibition, at one concentration (the size of the read-out at that concentration, not a potency): 0%
Compound 4: the middle estimate sits 17 percentage points above what was measured; measured number outside the range, below it.
By their numbers in this assay, from the lowest: compounds 4 and 3 (each within the scatter of the next); then compounds 1 and 2 (each within the scatter of the next).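

In this assay the change from 3-(dimethylamino)propyl to 2-(dimethylamino)ethyl goes with a number 23.8 percentage points lower from compound 1 to compound 4 (beyond the scatter) and leaves compound 4 at 0% in this series. The earlier compounds had shown no change on this chain, and this step shows that the reading responds to the length of the chain carrying the dimethylamino group, even with the other substituent on the nitrogen held fixed. It is also the second step, after a number 24 percentage points lower from compound 2 to compound 3 (beyond the scatter) among the compounds shown, in which a shorter chain on that nitrogen goes with a lower reading, and no compound shown goes against this. Nothing available here speaks to why the reading changes.

The compounds shown leave open whether a longer chain such as 4-(dimethylamino)butyl would raise the reading above that of compound 1. They also leave open whether a different amine at the chain end, such as a pyrrolidine or a morpholine, would hold the reading on the 3-carbon-named propyl chain.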